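The source may hold more compounds than are shown below. What is called first, only, known or untested is meant among the compounds shown, and "the series" means these compounds.

Compound 1 `CS(=O)(=O)CCCn1c(Cn2c(=O)n(C3COC3)c3ccncc32)cc2cc(Cl)ccc21` was tested in an ADME assay on HeLa cells (Homo sapiens) for cytotoxicity, read by ATP content, with a stated time of 3 days; on this read-out higher numbers stand for lower toxicity in this test and lower numbers for higher toxicity in this test. In this assay compound 1 gives > 50000 nM, which is a limit of the assay rather than a measured number. Its companion compound 2 `CS(=O)(=O)CCCn1c(Cn2c(=O)n(C3CC3)c3ccncc32)cc2cc(F)ccc21` was run in the same way. In this assay compound 2 gives > 50000 nM, again a limit and not a number. Going by the values given here, compound 1 therefore stands at the limit of what this assay can report, and so does the only other value shown, as the line the limit of > 50000 nM in this assay, at which 2 of the 2 values shown sit, records.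

Compound 3 `CC(C)(C)n1c(=O)n(Cc2cc3cc(Cl)ccc3n2CCCS(C)(=O)=O)c2cnccc21` has not yet been measured in this assay. It differs from compound 1 in one place: tert-butyl in place of oxetan-3-yl on an aromatic nitrogen. Among the compounds with values here, no step between two measured compounds is known here, so the size of the change from compound 1 to compound 3 can only be expected, not read off. Because both values shown sit at the limit of > 50000 nM in this assay, at which 2 of the 2 values shown sit, a step beyond the usual scatter is not expected in this assay, in either direction. Compound 3 is expected to give about 60000 nM, within a range from 30000 nM to 150000 nM, most likely again reported as a limit; the expected step that the limit leaves unreadable from compound 1 to compound 3 is essentially none.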

Compound 3, half-maximal cytotoxic concentration: > 50000 nM
Compound 3: no number, only a limit; the forecaster's own chance of this, stated with the estimate: 75%; the middle value lies beyond the limit too.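

Compound 1 and compound 3 both end at a limit of the assay rather than a number, so no step can be read for tert-butyl in place of oxetan-3-yl: the limit of > 50000 nM in this assay, at which 3 of the 3 values shown sit.

The compounds shown leave open how far apart they lie in this assay and at what concentration any of them would reach half-maximal cytotoxicity.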